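Chain extension in the chloromethyl ketone series: compound 3

The source may hold more compounds than are shown below. What is called first, only, known or untested is meant among the compounds shown, and "the series" means these compounds.

Measured so far:
compound 1 `CCCCCCCCSC[C@H](NC(C)=O)C(=O)CCl` — 4100 nM
compound 2 `CCCCCCCCCCCSC[C@H](NC(C)=O)C(=O)CCl` — 3000 nM

In a functional assay on MOLT-3 cells (Homo sapiens) (on this read-out higher numbers stand for weaker inhibition and lower numbers for stronger inhibition), compound 2 gives 3000 nM; compound 1 gives 4100 nM, and the two sit within the scatter of each other. Among the compounds with values here, the only step available is a 1.4-fold lower number from compound 1 to compound 2 (0.14 log units; within the scatter), a chain extension with no effect beyond scatter. Compound 3 `CCCCCCCCCCCCSC[C@H](NC(C)=O)C(=O)CCl` carries methyl in place of hydrogen on a saturated chain carbon, ten or more bonds along the chain from a sulfur, a smaller extension of the same chain. Nothing beyond scatter is expected, and compound 3 is therefore estimated at 2600 nM, range 1300 nM to 5500 nM. The expected step is a 1.2-fold lower number from compound 2 to compound 3 (0.06 log units; within the scatter).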

Compound 3, half-maximal inhibitory concentration: 2300 nM
Estimate against measurement, compound 3: 1.1-fold (0.05 log units) above; the range from low to high includes it.
By their numbers in this assay, from the lowest: compounds 3, 2 and 1 (each within the scatter of the next).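

Methyl in place of hydrogen on a saturated chain carbon gives a 1.3-fold lower number from compound 2 to compound 3 (0.12 log units; within the scatter) in this assay and so leaves this extension within the scatter. The larger change of chain gives a 1.8-fold lower number from compound 1 to compound 3 (0.25 log units; within the scatter) and shows that the widest span among these three chains also stays within the scatter. No supporting data bear on this flat read-out.

As far as these compounds go, whether a longer chain, or an amine or a carboxylic acid on this chain, would move the number beyond the scatter remains open. From the compounds shown here alone, the shared core stays constant throughout, so its contribution also remains open.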